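The compounds below may be only part of what the source reports. "The series", "measured", "known", "first", "only" and "open" are said of these compounds alone.

Series notes, four compounds on a shared core, one read-out.

Compound 1 `Cc1ccc(C)c(/C=C(/Sc2ccc(Br)cc2)C(=O)c2ccc(Cl)cc2)c1` is the reference. In a functional assay on DU-145 cells (Homo sapiens) for inhibition, read by trypan blue exclusion, with a stated time of 96 h (on this read-out higher numbers stand for weaker inhibition of growth and lower numbers for stronger inhibition of growth), compound 1 gives 10000 nM. Compound 2 `CN(C)c1ccc(/C=C(/Sc2ccc(Br)cc2)C(=O)c2ccc(Cl)cc2)cc1` carries 4-(dimethylamino)phenyl in place of 2,5-dimethylphenyl on a double-bonded chain carbon bound to a double-bonded chain carbon relative to compound 1. In this assay compound 2 gives only a limit of the assay, > 100000 nM, and not a number. As far as these compounds go, the step of an at least 10-fold higher number from compound 1 to compound 2 (1.00 log units; beyond the scatter) is the one fixed point for this change; how large it truly is stays open because the limit of > 100000 nM in this assay, at which 1 of the 3 values shown sits, caps what the assay reports.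

Compound 3 `Cc1ccc(C)c(/C=C(/SCc2ccc(Cl)cc2)C(=O)c2ccc(Cl)cc2)c1` differs from compound 1 by 4-chlorobenzyl in place of 4-bromophenyl on a sulfur. In this assay compound 3 gives 10000 nM, and the step of no change at the digits printed from compound 1 to compound 3 (within the scatter) says the two cores cannot be told apart on this read-out.

Compound 4 `CN(C)c1ccc(/C=C(/SCc2ccc(Cl)cc2)C(=O)c2ccc(Cl)cc2)cc1` is not yet measured. Relative to compound 3 it carries 4-(dimethylamino)phenyl in place of 2,5-dimethylphenyl on a double-bonded chain carbon bound to a double-bonded chain carbon, the same change as from compound 1 to compound 2, made at the same place and on a core that in this assay stands level with the core of compound 1. Within the data shown here, the expectation for compound 4 therefore rests on the single step of an at least 10-fold higher number from compound 1 to compound 2 (1.00 log units; beyond the scatter), and on compound 3 sitting at 10000 nM as the starting point.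

On that basis the step from compound 3 to compound 4 is expected to be a 10-fold higher number from compound 3 to compound 4 (1.00 log units; beyond the scatter) in this assay. Compound 4 is accordingly estimated at 100000 nM, with a plausible range of 30000 nM to 300000 nM, and a real chance that only a limit is returned.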

Compound 4, concentration for 50% growth inhibition: > 100000 nM
Compound 4 was reported as a limit; the forecaster's own chance of this, stated with the estimate: 60%; the middle value sits exactly at the limit.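

Compound 4 returns only a limit of the assay in this assay: > 100000 nM. On the shared core with 4-chlorobenzyl on the sulfur, 4-(dimethylamino)phenyl in place of 2,5-dimethylphenyl gives an at least 10-fold higher number from compound 3 to compound 4 (1.00 log units; beyond the scatter), so the change goes the same way on both cores shown: the same change on two cores in this assay, an at least 10-fold higher number (1.00 log units; beyond the scatter) from compound 1 to compound 2 and an at least 10-fold higher number (1.00 log units; beyond the scatter) from compound 3 to compound 4; the limit leaves it open whether they differ. What this does not show is how large the change truly is on either core or whether the two cores respond equally, and the step between the two compounds at the limit cannot be read: the limit of > 100000 nM in this assay, at which 2 of the 4 values shown sit.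

Still open, as far as these compounds go, is whether the step follows from the entry of the dimethylamino group or from the loss of the two methyl groups of 2,5-dimethylphenyl, since both pairs change these together. Also open, from the compounds shown here alone, is whether a phenyl ring carrying a methoxy group or a primary amine, in place of 4-(dimethylamino)phenyl, would give a readable number in this assay on either core.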